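The source may report more compounds than this note shows. Statements on the series, on what has been measured and on what is new or still open speak of the compounds shown alone.

Measured so far:
Compound 1, `C=C1[C@@H](OC(C)=O)C[C@@H]2[C@](C)(CO[Si](C)(C)C(C)(C)C)[C@H](OC(C)=O)CC[C@@]2(C)[C@@H]1C[C@@H](Nc1ccccc1)C1=CCOC1=O`, in a functional assay on MCF7 cells (Homo sapiens) for cytotoxicity, read by sulforhodamine B assay (a higher number here means a weaker inhibitor, a lower number a stronger inhibitor), gives 4840 nM.
Compound 2, `C=C1[C@@H](OC(C)=O)C[C@@H]2[C@](C)(COC=O)[C@H](OC(C)=O)CC[C@@]2(C)[C@@H]1C[C@@H](Nc1ccc(Br)cc1)C1=CCOC1=O`, in this assay gives 11400 nM.

Of the two numbers, compound 2 carries the higher one, and the gap to compound 1 lies beyond the scatter; the two compounds differ in more than one place, so nothing further is read from that pair. Compound 3, `C=C1[C@@H](OC(C)=O)C[C@@H]2[C@](C)(COC=O)[C@H](OC(C)=O)CC[C@@]2(C)[C@@H]1C[C@@H](Nc1cccc(F)c1)C1=CCOC1=O`, has not yet been measured. It differs from compound 2 by 3-fluorophenyl in place of 4-bromophenyl on an amine nitrogen. For the measured compounds named here, no step between measured compounds tells how such a change acts here, so for compound 3 the step of a 1.3-fold lower number from compound 2 to compound 3 (0.10 log units; within the scatter) is expected to stay within the scatter. Compound 3 is therefore estimated at 9000 nM, in the range 3000 nM to 27000 nM.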

Compound 3, half-maximal inhibitory concentration: 14100 nM
The estimate for compound 3 lay 1.6-fold (0.19 log units) below the measured number; the range from low to high includes it.
By their numbers in this assay, from the lowest: compound 1; then compounds 2 and 3 (each within the scatter of the next).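

In this assay, for the compounds shown here, the step of a 1.2-fold higher number from compound 2 to compound 3 (0.09 log units; within the scatter) gives the first reading of a single change on the amine nitrogen, with the rest of the shared core held constant. Here 3-fluorophenyl and 4-bromophenyl cannot be told apart, so this exchange of ring substituent and its place on the ring has no measurable effect on the number. Nothing available explains why the two groups read alike.

Only these two substituted phenyl groups can be compared on this core. From the compounds shown here alone, what a methoxy group or a carboxylic acid on the ring, or a pyridine ring in its place, would do remains open.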